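Swapping ethynyl for bromo in a weakly active compound

A few compounds are considered here, and "the series" means these few. Any claim that something is new, unique, unknown or untested is made for them only; others in the source may bear on it.

In a functional assay on A549 cells (Homo sapiens) for antiproliferative activity, read by MTT assay, with a stated time of 72 h (on this read-out higher numbers stand for weaker inhibition and lower numbers for stronger inhibition), compound 1 `COc1cc2ncnc(Nc3cccc(Br)c3)c2cc1OCCCN1CCNCCNCCNCC1` gives 14700 nM as a measured number. Compound 2 `C#Cc1cccc(Nc2ncnc3cc(OC)c(OCCCN4CCNCCNCC4)cc23)c1` stands at > 50000 nM in the same test, which is a limit of the assay and not a number. Compound 3 `COc1cc2ncnc(Nc3cccc(Br)c3)c2cc1OCCCN1CCNCCNCC1` differs from compound 2 in one place bromo in place of ethynyl on an aromatic carbon with bromo in place of ethynyl on an aromatic carbon. Compound 1 with its 3-bromophenyl group and its 14700 nM suggests that a modest move towards stronger inhibition is expected. In this assay the estimated step of an at least 1.7-fold lower number from compound 2 to compound 3 (0.25 log units; that floor lies within the scatter) remains a rough guide. Compound 3 is expected at 28000 nM with an estimated range from 12000 nM to 60000 nM around it.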

Compound 3, half-maximal inhibitory concentration: 34300 nM
The estimate for compound 3 lay 1.2-fold (0.09 log units) below the measured number; measured number inside the range.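

In this assay, bromo in place of ethynyl on this aromatic carbon gives an at least 1.4-fold lower number from compound 2 to compound 3 (0.16 log units; that floor lies within the scatter) and that is only a floor. Compound 2 is a limit and not a number, so the true size of this step cannot be read, because of where that compound sits: the limit of > 50000 nM in this assay, at which 1 of the 3 values shown sits.

With the 3-bromophenyl group kept, the ring at the end of the chain matters more clearly: the nine-membered ring gives a 2.3-fold higher number from compound 1 to compound 3 (0.37 log units; beyond the scatter) and so weaker inhibition than the larger ring. From the compounds shown here alone, whether chloro or an amine on the same aromatic carbon would shift the number stays open. So does how ethynyl behaves alongside the larger ring.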